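Swapping Hydroxy for Carboxy on the Shared Core

The source may report more compounds than this note shows. Statements on the series, on what has been measured and on what is new or still open speak of the compounds shown alone.

Compound 1 `CCOc1ccc2nc(C(=O)Nc3c(F)cc(-c4cccc(F)c4)cc3F)c(C)c(O)c2c1` was tested in a functional assay on A-375 cells (Homo sapiens) for antiproliferative activity, read by MTT assay, with a stated time of 24 h, tested at 0.01 ug/mL (a higher number here means a stronger effect of the compound at the concentration tested, a lower number a weaker effect), and gives 0.23%, a read-out so small that the compound shows hardly any effect at this concentration. Its only measured companion, compound 2 `Cc1c(C(=O)Nc2c(F)cc(-c3cccc(F)c3)cc2F)nc2ccc(C(F)(F)F)cc2c1O`, gives 0.16% in this assay, and the two numbers sit within the scatter of each other: the change a number 0.1 percentage points lower from compound 1 to compound 2 (within the scatter) is too small to mean anything. Compound 3 `CCOc1ccc2nc(C(=O)Nc3c(F)cc(-c4cccc(F)c4)cc3F)c(C)c(C(=O)O)c2c1` is the next compound, still to be measured. It differs from compound 1 in one place: carboxy in place of hydroxy on an aromatic carbon. Among the measured compounds shown here, no measured step touches this position, so nothing in the data speaks for a change either way. For the measured compounds named here, since the only known step, that from compound 1 to compound 2, stayed within the scatter, the expectation is a step of a number 0.1 percentage points higher from compound 1 to compound 3 (within the scatter), again within the scatter. Compound 3 is therefore estimated at 0.3%, within the range 0% to 8%.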

Compound 3, a percentage reported as inhibition, at one concentration (the size of the read-out at that concentration, not a potency): 0.3%
The estimate for compound 3 equals the measured number at the digits printed; low and high end bracket the measured number.
By their numbers in this assay, from the lowest: compounds 2, 1 and 3 (each within the scatter of the next).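

Among the compounds shown here, replacing hydroxy with carboxy on the aromatic carbon opposite the ring nitrogen gives a number 0.1 percentage points higher from compound 1 to compound 3 (within the scatter) in this assay, and this is the only measured step at this position. Carboxy brings 3 heavy atoms where hydroxy has 1, yet at this single low concentration the read-outs of the two compounds cannot be told apart, so this swap leaves no measurable mark here. No supporting measurement is available to explain this result.

On these data alone, since compound 1 already shows hardly any effect at this concentration, it remains open whether the two groups would differ at a concentration where the compounds act more strongly. As far as these compounds go, it is also open how an amine or a methoxy group on the same carbon would read out in this assay.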